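Swapping a Methylcyclohexyl Amide for a Dimethylmorpholine Urea

The source may report more compounds than this note shows. Statements on the series, on what has been measured and on what is new or still open speak of the compounds shown alone.

Compound 1 `CC1CCC(C(=O)N2CC(c3nc(-c4cccc(Cl)c4)no3)C2)CC1`: 1500 nM
Compound 2 `O=C(C1CCC(C(F)(F)F)CC1)N1CC(c2nc(-c3cccc(Cl)c3)no2)C1`: 1000 nM
Compound 3 `Cc1cccc(-c2noc(C3CN(C(=O)c4ccccc4F)C3)n2)c1`: > 10000 nM, which is a limit of the assay and not a number.

All three were tested in an assay on HEK293 cells for positive allosteric modulation of metabotropic glutamate receptor 5 (Homo sapiens), read by FLIPR; on this read-out lower numbers stand for an effect already at smaller amounts and higher numbers for an effect only at larger amounts of compound. Compound 1 and compound 2 share the same core and differ only on a saturated ring carbon; their step of a 1.5-fold lower number from compound 1 to compound 2 (0.18 log units; within the scatter) lies within the scatter, so the two numbers given stand side by side rather than in any order. Compound 3 reaches only the limit of this assay. It differs from compound 1 in more than one place, so no single step can be read from it.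

Compound 4 `CC1CN(C(=O)N2CC(c3nc(-c4cccc(Cl)c4)no3)C2)CC(C)O1` has not yet been measured. It differs from compound 1 in one place: 2,6-dimethylmorpholin-4-yl in place of 4-methylcyclohexyl on a carbonyl carbon. For the measured compounds named here, no measured step touches this part of the molecule in a comparable way: the only measured step, a 1.5-fold lower number from compound 1 to compound 2 (0.18 log units; within the scatter), exchanges one small group for another on the saturated ring and stays within the scatter. The change into compound 4 replaces a ring of carbon only with one carrying two hetero atoms and an acceptor, a larger alteration than anything measured here. A moderate loss is therefore expected, a 2.0-fold higher number from compound 1 to compound 4 (0.30 log units; within the scatter), with wide uncertainty. For compound 4 the expected value in this assay is 3000 nM, estimated to lie between 800 nM and 12000 nM.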

Compound 4, half-maximal effective concentration: > 10000 nM
Compound 4: a limit, no number; the forecaster's own chance of this, stated with the estimate: 25%; middle value at least 3.3-fold (0.52 log units) from the limit.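

Exchanging 4-methylcyclohexyl for 2,6-dimethylmorpholin-4-yl on the carbonyl carbon gives an at least 6.6-fold higher number from compound 1 to compound 4 (0.82 log units; beyond the scatter) in this assay. This shows that this position does not accept every six-membered ring, whereas the earlier step, a 1.5-fold lower number from compound 1 to compound 2 (0.18 log units; within the scatter), showed no change that could be told from the scatter. Compound 4 gives > 10000 nM, which is a limit of the assay and not a number.

How far the loss really goes cannot be read, and this limit is shared by more than one compound: the limit of > 10000 nM in this assay, at which 2 of the 4 values shown sit.

The compounds shown also leave open which part of the exchange matters, the ring oxygen, the ring nitrogen bound to the carbonyl carbon, or the two methyl groups. A piperidin-1-yl group on the same carbonyl carbon would test the ring nitrogen without the ring oxygen, while an unsubstituted morpholin-4-yl group would test the ring hetero atoms without the two methyl groups.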